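A few compounds are considered here, and "the series" means these few. Any claim that something is new, unique, unknown or untested is made for them only; others in the source may bear on it.

Measured in an ADME assay on Raji cells (Homo sapiens) for cytotoxicity, with a stated time of 72 h; a higher number here means that more compound is needed for the effect, a lower number that less compound is needed:
compound 1, `Cc1cc(NC(=O)Nc2ccc(C(F)(F)F)cc2)c2ccccc2n1`, gives 23000 nM;
compound 2, `COC(=O)c1cccc(NC(=O)Nc2cc(C)nc3ccccc23)c1`, gives 26000 nM;
compound 3, `Cc1cc(NC(=O)Nc2ccc(OC(F)(F)F)cc2)c2ccccc2n1`, gives 10000 nM.

Compound 2 gives the largest of the three numbers, but compound 1 lies within the scatter of it, so the two cannot be told apart; only compound 3 lies beyond the scatter below it. Compound 4, `Cc1cc(NC(=O)Nc2cccc(Cl)c2)c2ccccc2n1`, differs from compound 2 by chloro in place of methoxycarbonyl on an aromatic carbon. Within the data shown here, no measured step covers this exact exchange. Among the measured compounds shown here, the one measured step, a 2.3-fold lower number from compound 1 to compound 3 (0.36 log units; beyond the scatter), shows that swapping one group for another on an aromatic carbon moved this assay only modestly, and all three numbers sit close together. For compound 4 the number is therefore expected to change little, a 1.3-fold lower number from compound 2 to compound 4 (0.11 log units; within the scatter), with an estimate of 20000 nM and a range from 7000 nM to 60000 nM.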

Compound 4, half-maximal effective concentration: 18000 nM
For compound 4 the middle estimate is 1.1-fold (0.05 log units) above the measured one; measured number inside the range.
By their numbers in this assay, from the lowest: compounds 3, 4, 1 and 2 (each within the scatter of the next, the first and the last beyond it).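

In this assay, methoxycarbonyl, with 4 heavy atoms and 2 hydrogen-bond acceptors, gives way to chloro, with 1 heavy atom and 0 hydrogen-bond acceptors, on an aromatic carbon meta to a large group, and the result is a 1.4-fold lower number from compound 2 to compound 4 (0.16 log units; within the scatter). Even this exchange of a larger group for a single atom therefore leaves no difference that can be told from the scatter. No measurement here offers an explanation for this.

On these data alone, it remains open whether an amine, a carboxylic acid or a longer chain at this position would move the number beyond the scatter.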